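A Dichlorophenyl Variant of a Full Histamine Agonist

The source may hold more compounds than are shown below. What is called first, only, known or untested is meant among the compounds shown, and "the series" means these compounds.

Measured compounds:
Compound 1, `N=C(NCCCc1c[nH]cn1)NCCC(c1cccc(F)c1)c1ccccn1`: 1
Compound 2, `N=C(NCCCc1c[nH]cn1)NCCC(c1cc(F)cc(F)c1)c1ccccn1`: 1

In a functional assay on cardiac atrium for agonist activity at histamine H2 receptor (Cavia porcellus) (on this read-out lower numbers stand for smaller maximal responses and higher numbers for larger maximal responses), compound 1 gives 1, and compound 2 gives 1, so compound 2 stands level with compound 1 and both reach the full response of the reference agonist. For the measured compounds named here, the one step between them, no change at the digits printed from compound 1 to compound 2 (within the scatter), came from putting fluoro in place of hydrogen on an aromatic carbon and left the maximal response unchanged within the scatter.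

Compound 3, `N=C(NCCCc1c[nH]cn1)NCCC(c1ccc(Cl)c(Cl)c1)c1ccccn1`, is not yet measured. It differs from compound 2 by 3,4-dichlorophenyl in place of 3,5-difluorophenyl on a saturated chain carbon bound to an aromatic carbon and a saturated chain carbon. Going by the values given here, the only measured step that bears on this change is the one from compound 1 to compound 2, which also altered the phenyl group on that saturated chain carbon without moving the read-out. The new exchange is larger, replacing both halogens and their arrangement, yet nothing measured points to a loss of maximal response, so in this assay compound 3 is expected to show a number 0.050 lower from compound 2 to compound 3 (within the scatter), no change beyond the scatter. Compound 3 is therefore estimated at 0.95, with a range from 0.75 to 1.05.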

Compound 3, intrinsic activity: the largest response reached, as a fraction of the reference agonist's: 1
For compound 3 the middle estimate is 0.050 below the measured one, within the range that was stated.
By their numbers in this assay, from the lowest: compounds 1, 2 and 3 (each within the scatter of the next).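

In this assay, 3,4-dichlorophenyl in place of 3,5-difluorophenyl on a saturated chain carbon bound to an aromatic carbon and a saturated chain carbon brought no change at the digits printed from compound 2 to compound 3 (within the scatter), and 3,4-dichlorophenyl in place of 3-fluorophenyl at the same place brought no change at the digits printed from compound 1 to compound 3 (within the scatter). The earlier compounds shown here showed only fluorine-bearing phenyl groups here, whereas these steps show that a chlorine-bearing phenyl group with a different substitution pattern also stays level with them on the maximal response. Nothing available explains why the response stays level.

On these data alone, whether a phenyl ring carrying an amine or a carboxylic acid at this place would keep the same maximal response remains open. This read-out also leaves open how much of each compound is needed to reach that response.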